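Lengthening the hydroxycarbamoyl chain of compound 2

The source may hold more compounds than are shown below. What is called first, only, known or untested is meant among the compounds shown, and "the series" means these compounds.

In a functional assay on HepG2 cells (Homo sapiens) for antiproliferative activity, read by MTT assay, with a stated time of 96 h (a higher number here means a weaker inhibitor of growth, a lower number a stronger inhibitor of growth), compound 1 (`Cc1ccc(-c2cc(C)nn2Cc2ccc(C(=O)NO)cc2)cc1`) gives 13300 nM. Compound 2 (`O=C(CCNC(=O)c1cc(-c2ccc(F)cc2)[nH]n1)NO`) gives 76000 nM, the higher of the two numbers, and the gap lies beyond the scatter. Compound 3 (`O=C(CCCCNC(=O)c1cc(-c2ccc(F)cc2)[nH]n1)NO`) extends the chain of compound 2: 2-(hydroxycarbamoyl)ethyl in place of hydroxycarbamoyl on a saturated chain carbon, two bonds along the chain from an amide-type nitrogen. Among the compounds with values here, no measured pair shows this change, so the expectation is a judgement from the structures alone. In this assay a lower number, beyond the scatter, is expected, with the estimated step of a 4.2-fold lower number from compound 2 to compound 3 (0.63 log units; beyond the scatter). For compound 3 the estimate is 18000 nM, with an expected range of 4500 nM to 70000 nM.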

Compound 3, concentration for 50% growth inhibition: > 100000 nM
Compound 3: no number, only a limit; the forecaster's own chance of this, stated with the estimate: 10%; middle value at least 5.5-fold (0.74 log units) away from the limit.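

In this assay, 2-(hydroxycarbamoyl)ethyl in place of hydroxycarbamoyl brings no lower number at this position, and the longer chain gives no gain in growth inhibition over compound 2: the change reads as an at least 1.3-fold higher number from compound 2 to compound 3 (0.11 log units; that floor lies within the scatter). Compound 3 gives > 100000 nM, which is a limit and not a number. Only a floor can be read for the step, and a real weakening is not established: the limit of > 100000 nM in this assay, at which 1 of the 3 values shown sits.

Open, on these data alone, is how the number moves with a chain one carbon longer than that of compound 2, or with a carboxylic acid in place of hydroxycarbamoyl.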